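A few compounds are considered here, and "the series" means these few. Any claim that something is new, unique, unknown or untested is made for them only; others in the source may bear on it.

Three compounds sharing one core were measured in an assay on isolated protein for inhibition of histone deacetylase 4 (Homo sapiens), with a stated time of 1 h; a higher number here means a weaker inhibitor, a lower number a stronger inhibitor:

Compound 1 `Cc1ccc(NC(=O)COc2ccc3cc(/C=C4/SC(=O)NC4=O)ccc3c2)cc1`: 1700 nM
Compound 2 `O=C(COc1ccc2cc(/C=C3/SC(=O)NC3=O)ccc2c1)Nc1cccc(Cl)c1`: 3800 nM
Compound 3 `O=C(COc1ccc2cc(/C=C3/SC(=O)NC3=O)ccc2c1)Nc1ccc(Br)cc1`: 2900 nM

Compound 3 stands second highest of these three numbers. One neighbouring step is a 1.3-fold lower number from compound 2 to compound 3 (0.12 log units; within the scatter), within the scatter, and the other is a 1.7-fold higher number from compound 1 to compound 3 (0.23 log units; within the scatter), also within the scatter, so the three values lie close together. Among the compounds with values here, the only step beyond the scatter is a 2.2-fold higher number from compound 1 to compound 2 (0.35 log units; beyond the scatter), which exchanges the whole aryl group on the amide-type nitrogen for one carrying a halogen at another place.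

Compound 4 `O=C(COc1ccc2cc(/C=C3/SC(=O)NC3=O)ccc2c1)Nc1ccc(F)cc1` differs from compound 3 in one place: fluoro in place of bromo on an aromatic carbon. Within the data shown here, the step most directly comparable is the one from compound 1 to compound 3, where bromo replaced methyl on the same aromatic carbon and the number moved only within the scatter. The step from compound 2 to compound 3, which also ends at the bromo compound, likewise stayed within the scatter. On this basis, swapping one halogen for another at the same carbon is expected to give no step beyond the scatter, a 1.0-fold higher number from compound 3 to compound 4 (0.01 log units; within the scatter). The estimate for compound 4 in this assay is 3000 nM, with a range of 1500 nM to 6000 nM.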

Compound 4, half-maximal inhibitory concentration: 1600 nM
For compound 4 the middle estimate is 1.9-fold (0.27 log units) above the measured one, within the range that was stated.
By their numbers in this assay, from the lowest: compounds 4, 1, 3 and 2 (each within the scatter of the next, the first and the last beyond it).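

In this assay the aromatic carbon para to a large group has now carried methyl, bromo and fluoro, and no exchange among them leaves the scatter, with a 1.8-fold lower number from compound 3 to compound 4 (0.26 log units; within the scatter) for fluoro in place of bromo and a 1.1-fold lower number from compound 1 to compound 4 (0.03 log units; within the scatter) for fluoro in place of methyl. The earlier compounds shown here showed this tolerance only for bromo against methyl, and the result extends it to a second halogen, so the size of the atom count aside, this exchange of bromo for fluoro, one heavy atom for one, does not separate the two compounds. The new compound also gives a second step beyond the scatter, a 2.4-fold lower number from compound 2 to compound 4 (0.38 log units; beyond the scatter) for 4-fluorophenyl in place of 3-chlorophenyl on the amide-type nitrogen, although compound 3 goes against any clean split of compound 2 from the rest, since its step from compound 2 stays within the scatter.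

Going by these compounds, whether an amine, a carboxylic acid or a methoxy group on this same carbon would stay in so narrow a band remains open, as does how fluoro would read at the place that chloro holds in compound 2. Nothing given here bears on why these steps take the sizes they do.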